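Changing the ring group on compound 2

A few compounds are considered here, and "the series" means these few. Any claim that something is new, unique, unknown or untested is made for them only; others in the source may bear on it.

- compound 1 `CN1CCN(c2ccc3c(c2)oc(=O)n3C(=O)NCCCCc2ccccc2)C(=O)C1` gives 20000 nM
- compound 2 `CC(C)CN1CCC(c2ccc3c(c2)oc(=O)n3C(=O)NCCCCc2ccccc2)CC1` gives < 1000 nM as a limit

In a physicochemical assay for solubility, read by HPLC, in phosphate buffer, measured as kinetic solubility, with a stated time of 1 h, at pH 7.4, tested at 250 uM (a lower number here means a less soluble compound, a higher number a more soluble compound), both compounds have been read. Compound 2 reads < 1000 nM which is a limit of the assay and not a number, so it stands at the low end of the two.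

Compound 3 `CCN1CCN(c2ccc3c(c2)oc(=O)n3C(=O)NCCCCc2ccccc2)CC1` keeps the shared core and carries 4-ethylpiperazin-1-yl in place of 1-isobutylpiperidin-4-yl on an aromatic carbon. Among the measured compounds shown here, the one measured step at this place is an at least 20-fold lower number from compound 1 to compound 2 (1.30 log units; beyond the scatter) and it was large. The entering group resembles the 4-methyl-2-oxopiperazin-1-yl of compound 1 with its 20000 nM so a sizeable move back upward in this assay is expected. The expected step is an at least 6.0-fold higher number from compound 2 to compound 3 (0.77 log units; beyond the scatter) and it rests on that single comparison. For compound 3 the estimated value is 6000 nM with an expected range from 1500 nM to 20000 nM in this assay for now.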

Compound 3, solubility: < 1000 nM
Compound 3 gave a limit, no number; the forecaster's own chance of this, stated with the estimate: 20%; middle value at least 6.0-fold (0.77 log units) from the limit.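

In this assay, a ring with two nitrogens at this position does not by itself bring back the higher reading, as 4-ethylpiperazin-1-yl in place of 4-methyl-2-oxopiperazin-1-yl gives an at least 20-fold lower number from compound 1 to compound 3 (1.30 log units; beyond the scatter). The step between compound 2 and compound 3 cannot be read, since both values are limits and not numbers. Within this set, compound 1 alone stands clear of the shared floor, while the piperidine of compound 2 and the piperazine of compound 3 both end up there: the limit of < 1000 nM in this assay, at which 2 of the 3 values shown sit.

As far as these compounds go, how far compound 2 and compound 3 lie under that limit stays open, and so does their order. Compound 1 differs from compound 3 in both its ring carbonyl and its methyl, so a 4-methylpiperazin-1-yl group at this place could help separate the two.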